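The compounds below may be only part of what the source reports. "The series", "measured", "known", "first", "only" and "open" are said of these compounds alone.

Measured compounds:
- compound 1 `Cc1nc(SCC(=O)Nc2nc(-c3ccc(Cl)cc3)cs2)n(Nc2ccccc2)c1C` — 20900 nM in a functional assay on BT-549 cells (Homo sapiens) for antiproliferative activity, read by sulforhodamine B assay, with a stated time of 48 h; a higher number here means a weaker inhibitor of growth, a lower number a stronger inhibitor of growth
- compound 2 `Cc1ccc(Nn2c(SCC(=O)Nc3nc(-c4ccccc4)cs3)nc(C)c2C)cc1` — 14100 nM

Two compounds of this series carry a number. Compound 1, `Cc1nc(SCC(=O)Nc2nc(-c3ccc(Cl)cc3)cs2)n(Nc2ccccc2)c1C`, gives the higher of the two numbers in this assay, with 20900 nM, and compound 2, `Cc1ccc(Nn2c(SCC(=O)Nc3nc(-c4ccccc4)cs3)nc(C)c2C)cc1`, gives 14100 nM; the gap between them lies within the usual scatter of repeated measurements, so the two compounds cannot be ranked against each other on these figures. Going by the values given here, no single-point step between measured compounds is available, since compound 2 differs from compound 1 in more than one place.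

Compound 3, `COc1ccc(Nn2c(SCC(=O)Nc3nc(-c4ccc(Cl)cc4)cs3)nc(C)c2C)cc1`, has not yet been measured. It differs from compound 1 by one change: methoxy in place of hydrogen on an aromatic carbon. Among the compounds with values here, there is no measured pair that isolates this change, so there is nothing to show whether it moves the number at all. Compound 3 is therefore expected to stay close to compound 1, with a 1.3-fold lower number from compound 1 to compound 3 (0.12 log units; within the scatter) as the step that the estimate means, not beyond the scatter in either direction. For compound 3 the expected concentration for total growth inhibition in this assay is 16000 nM, within an estimated range from 6000 nM to 40000 nM.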

Compound 3, concentration for total growth inhibition: 82000 nM
For compound 3 the middle estimate is 5.1-fold (0.71 log units) below the measured one, outside the stated range (above it).
By their numbers in this assay, from the lowest: compounds 2 and 1 (each within the scatter of the next); then compound 3.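

In this assay, the change from anilino to (4-methoxyphenyl)amino comes with a 3.9-fold higher number from compound 1 to compound 3 (0.59 log units; beyond the scatter), so this aromatic carbon, para to a large group, does not accept methoxy in place of hydrogen without a loss in growth inhibition. Going by these compounds alone, the earlier compounds could not show this: compound 1 and compound 2 differ in more than one place and their values lie within the scatter of each other, so this is the first step that isolates a single change. No measurement is at hand that would explain the step.

The step rests on one group at one carbon, on the background of compound 1, and compound 2 cannot extend it, as its methyl on the same ring comes with a second difference elsewhere in the molecule. Going by these compounds, whether hydroxy, fluorine or an amine at this carbon would move the number in the same way stays open, as does whether methoxy would do so on another carbon of that ring.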